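Carbonyl substituent change from compound 3 to compound 4

The source may hold more compounds than are shown below. What is called first, only, known or untested is meant among the compounds shown, and "the series" means these compounds.

Measured in a functional assay on PC-3 cells (Homo sapiens), read by MTT assay, with a stated time of 48 h; a higher number here means a weaker inhibitor, a lower number a stronger inhibitor:
Compound 1 `CCn1c(C(=O)NCC(OC)OC)ccc1C(CC)(CC)c1ccc(OCC(O)C(C)(C)C)c(C)c1`: 14600 nM
Compound 2 `CCn1c(C(=O)N(C)CCC#N)ccc1C(CC)(CC)c1ccc(OCC(O)C(C)(C)C)c(C)c1`: 1700 nM
Compound 3 `C=CCN(C)C(=O)c1ccc(C(CC)(CC)c2ccc(OCC(O)C(C)(C)C)c(C)c2)n1CC`: 25900 nM

The high end of the range is shared, with a 1.8-fold higher number from compound 1 to compound 3 (0.25 log units; within the scatter). The gap to the low end is wide, with a 15-fold higher number from compound 2 to compound 3 (1.18 log units; beyond the scatter).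

Compound 4 `CCn1c(C(=O)Oc2ccc(CCO)cc2)ccc1C(CC)(CC)c1ccc(OCC(O)C(C)(C)C)c(C)c1` differs from compound 3 by a group of 10 heavy atoms (8 carbon, 2 oxygen; one six-membered aromatic ring of carbon only) in place of a group of 5 heavy atoms (4 carbon, 1 nitrogen; no ring), on a carbonyl carbon. Among the measured compounds shown here, the entering group holds a six-membered aromatic ring of carbon only, and no measured compound has such a ring in the group on this carbonyl carbon. The measured steps therefore bear on it only indirectly.

Exchanges of the group on the carbonyl carbon have given both outcomes: an 8.6-fold lower number from compound 1 to compound 2 (0.93 log units; beyond the scatter), but also the step from compound 1 to compound 3 that stays within the scatter. The group clearly can move the number, and compound 3 already sits at the high end of what has been seen, so a modest move towards a lower number is expected in this assay, with wide uncertainty. The expected step is a 3.2-fold lower number from compound 3 to compound 4 (0.51 log units; beyond the scatter). For compound 4 the value is estimated at 8000 nM, with an expected range of 1800 nM to 30000 nM.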

Compound 4, half-maximal inhibitory concentration: 6300 nM
Beside the measured number, compound 4's estimate is 1.3-fold (0.10 log units) above it; the measured number falls inside the stated range.
By their numbers in this assay, from the lowest: compound 2; then compound 4; then compounds 1 and 3 (each within the scatter of the next).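

In this assay, a group with no nitrogen and a six-membered aromatic ring of carbon only can replace allyl(methyl)amino on this carbonyl carbon, with a 4.1-fold lower number from compound 3 to compound 4 (0.61 log units; beyond the scatter). The same group also gives a 2.3-fold lower number from compound 1 to compound 4 (0.37 log units; beyond the scatter), but a 3.7-fold higher number from compound 2 to compound 4 (0.57 log units; beyond the scatter), so the ring-bearing group lands in the middle of the series while the (2-cyanoethyl)(methyl)amino group of compound 2 keeps the lowest number; heavy-atom count does not order these groups, since compound 4 carries more heavy atoms than compound 2 and also more than compound 3, yet its number lies above the first and below the second. No measurement in hand accounts for any of these steps.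

The compounds shown do not separate the contribution of the aromatic ring from that of its hydroxyl-bearing chain, or from that of the oxygen joining the group to the carbonyl carbon. A plain phenoxy group and a benzylamino group on this carbonyl carbon would address those two questions, and a carboxylic acid there would show how the series responds to a much smaller group.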